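Swapping the amide substituent in the acid series

The compounds below may be only part of what the source reports. "The series", "measured", "known", "first", "only" and "open" are said of these compounds alone.

Among the measured compounds shown here, in an ADME assay on L02 cells (Homo sapiens) for cytotoxicity, read by MTT assay, with a stated time of 48 h (on this read-out lower numbers stand for stronger inhibition and higher numbers for weaker inhibition), compound 1 `CCN(CC)CCCNC(=O)c1ccc(C(CC)(CC)c2ccc(OCC(=O)C(C)(C)C)c(C)c2)n1CC` gives 2300 nM and compound 2 `CC[C@@H](C)[C@H](NC(=O)c1ccc(C(CC)(CC)c2ccc(OCC(=O)C(C)(C)C)c(C)c2)n1CC)C(=O)O` gives 1500 nM, so compound 2 stands within the scatter of the only other measured value. Compound 3 `CCn1c(C(=O)N(C)CC(=O)O)ccc1C(CC)(CC)c1ccc(OCC(=O)C(C)(C)C)c(C)c1` has (carboxymethyl)(methyl)amino in place of (1-carboxy-2-methylbutyl)amino on a carbonyl carbon. For the measured compounds named here, the one measured step bearing on this, a 1.5-fold lower number from compound 1 to compound 2 (0.19 log units; within the scatter), also replaced the substituent on the amide-type nitrogen, so no change beyond the scatter is expected. The expected step is a 1.3-fold higher number from compound 2 to compound 3 (0.12 log units; within the scatter). Compound 3 is estimated at 2000 nM, with an expected range of 900 nM to 6000 nM.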

Compound 3, half-maximal inhibitory concentration: 8700 nM
The estimate for compound 3 lay 4.4-fold (0.64 log units) below the measured number, outside the stated range (above it).
By their numbers in this assay, from the lowest: compounds 2 and 1 (each within the scatter of the next); then compound 3.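

In this assay the step of a 5.8-fold higher number from compound 2 to compound 3 (0.76 log units; beyond the scatter) and the step of a 3.8-fold higher number from compound 1 to compound 3 (0.58 log units; beyond the scatter) both lie beyond the scatter, so the substituent at this position can move the number, which the earlier step within the scatter did not show. Compound 3, carrying (carboxymethyl)(methyl)amino on the carbonyl carbon, has the highest number of the three. Nothing available explains this shift.

Compound 3 differs from compound 2 in both the side chain and the loss of the amide hydrogen, so the part responsible remains unresolved. A (carboxymethyl)amino group, which keeps the amide hydrogen, would separate the two.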